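The source may hold more compounds than are shown below. What is called first, only, known or untested is meant among the compounds shown, and "the series" means these compounds.

Compound 1 `Cc1ccc(-c2nc(CNc3ccc(C(=O)NO)cc3)n(-c3ccccc3)n2)cc1` was tested in an assay on Sf9 cells for inhibition of protein deacetylase HDAC6 (Homo sapiens), read by fluorescence, with a stated time of 40 min, tested at 100 nM (on this read-out higher numbers stand for more inhibition at the one concentration tested (going by the name of the read-out) and lower numbers for less inhibition), and gives 62.2%. Compound 2 `O=C(O)c1ccc(NCc2nc(-c3ccccc3)nn2-c2ccccc2)cc1` in this assay gives -0.4%, so compound 1 stands highest of the two numbers, and the gap to compound 2 lies beyond the scatter. For the measured compounds named here, no two measured compounds differ in only one place, so no single-change step has been measured.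

Compound 3 `Cc1ccsc1-c1nc(CNc2ccc(C(=O)NO)cc2)n(-c2ccccc2)n1` has not yet been measured. Compared with compound 1, the change is 3-methylthiophen-2-yl in place of 4-methylphenyl on an aromatic carbon. Going by the values given here, both the group that leaves and the group that enters are single aromatic rings, and no measured pair shows what such a swap at this position does. The expected step of a number 5.2 percentage points lower from compound 1 to compound 3 (within the scatter) in this assay is small, probably none beyond the scatter, with at most a slight loss. Compound 3 is therefore estimated at 57%, with a range from 40% to 74%.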

Compound 3, a percentage reported as inhibition, at one concentration (the size of the read-out at that concentration, not a potency): 72.1%
The estimate for compound 3 lay 15.1 percentage points below the measured number; the measured number falls inside the stated range.
By their numbers in this assay, from the lowest: compound 2; then compounds 1 and 3 (each within the scatter of the next).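

In this assay, for the compounds shown here, the step of a number 9.9 percentage points higher from compound 1 to compound 3 (within the scatter) is the first single-change step, and it leaves the two compounds indistinguishable. On the aromatic carbon between two ring nitrogen atoms, 3-methylthiophen-2-yl, a five-membered aromatic ring with a sulfur atom, can therefore take the place of 4-methylphenyl, a six-membered carbon ring, with no change beyond the scatter. Nothing available here explains why the two rings read alike.

As far as these compounds go, both groups tested at this carbon are single aromatic rings bearing a methyl group, so the effect of a non-aromatic group there, such as a cyclohexyl ring, an amine or a longer alkyl chain, remains open. Whether the methyl group on the thiophene ring matters also stays unknown, since an unsubstituted thiophen-2-yl group is not among the compounds shown.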